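Swapping the Benzyl Ring on a Cell-Tolerated Amide

A few compounds are considered here, and "the series" means these few. Any claim that something is new, unique, unknown or untested is made for them only; others in the source may bear on it.

Compound 1 `Cc1cc(C)cc(S(=O)(=O)c2c(C(=O)NCc3ccc(F)cc3)[nH]c3ccc(Cl)cc23)c1`: > 53000 nM
Compound 2 `Cc1cc(C)cc(S(=O)(=O)c2c(C(=O)NCc3ccc([N+](=O)[O-])cc3)[nH]c3ccc(Cl)cc23)c1`: > 50200 nM

Both values come from an ADME assay on MT4 cells (Homo sapiens) for cytotoxicity, read by MTT assay; a lower number here means that less compound is tolerated, a higher number that more compound is tolerated. Compound 2 stands at > 50200 nM, which is a limit and not a number. Compound 1 stands at > 53000 nM, which is also a limit. The two compounds therefore give no exact position on the scale, only two limits.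

Compound 3 `Cc1cc(C)cc(CNC(=O)c2[nH]c3ccc(Cl)cc3c2S(=O)(=O)c2cc(C)cc(C)c2)c1` keeps the shared core of compound 2 and changes one group: 3,5-dimethylphenyl in place of 4-nitrophenyl on a saturated chain carbon bound to an amide-type nitrogen. In words, 3,5-dimethylphenyl comes in place of 4-nitrophenyl on a saturated chain carbon bound to an amide-type nitrogen.

For the measured compounds named here, only one measured step bears on this change, a step that the two limits leave unreadable from compound 1 to compound 2, where nitro replaces fluoro on an aromatic carbon. Its size cannot be read, so it gives no direction. With compound 2 at a limit of > 50200 nM, no step beyond the scatter is expected in this assay. The estimated a number no higher from compound 2 to compound 3 (the limit leaves the size open) is accordingly small and has no expected direction, and a further limit is the likeliest report. For compound 3 the expected value is 50000 nM, within an estimated range of 15000 nM to 60000 nM.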

Compound 3, half-maximal cytotoxic concentration: > 51900 nM
Compound 3 ended at the assay's limit; the forecaster's own chance of this, stated with the estimate: 70%; middle value at least 1.0-fold (0.01 log units) away from the limit.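

For the compounds shown here, compound 1, compound 2 and compound 3 each give only a limit in this assay, and no step between them can be read. The compounds shown leave open the actual half-maximal cytotoxic concentration of each one, and whether changing the group on the amide nitrogen shifts it at all.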